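Shortening the side chain of an aziridinylquinone

This account rests on a few compounds, and the source may have more. Where it says the series, first, only, none or still open, it means among the compounds named here.

The measured compounds:
- Compound 1 `CC1=C(N2CC2)C(=O)C(C(C)COC(N)=O)=C(N2CC2)C1=O` gives 5.31 in a functional assay on L1210 cells (Mus musculus), with a stated time of 1 days; a higher number here means a more potent compound, by a factor of ten per unit of this negative logarithm, a lower number a less potent compound.
- Compound 2 `CCC(OC)C1=C(N2CC2)C(=O)C(C)=C(N2CC2)C1=O` gives 4.84 in this assay.
- Compound 3 `CCC(COC(N)=O)C1=C(N2CC2)C(=O)C(C)=C(N2CC2)C1=O` gives 5.2 in this assay.

Compound 2 stands lowest of the three in this assay: its nearest neighbour is compound 3, with the step of a number 0.36 log units higher from compound 2 to compound 3 (beyond the scatter), and its furthest is compound 1, since a number 0.47 log units lower from compound 1 to compound 2 (beyond the scatter).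

Compound 4 `COCCC1=C(N2CC2)C(=O)C(C)=C(N2CC2)C1=O` has not yet been measured. Its change from compound 2 is 2-methoxyethyl in place of 1-methoxypropyl on a double-bonded ring carbon. For the measured compounds named here, the methoxy group stays, so the only measured step that speaks to this change is the one altering the chain itself: a number 0.11 log units lower from compound 1 to compound 3 (within the scatter). That step lay within the scatter, which suggests that adding or removing one carbon on this chain does little. The replacement steps a number 0.47 log units lower from compound 1 to compound 2 (beyond the scatter) and a number 0.36 log units higher from compound 2 to compound 3 (beyond the scatter) were modest and concern a different part of the group, so they give only a loose frame.

For compound 4 in this assay the expectation is therefore a step of a number 0.06 log units higher from compound 2 to compound 4 (within the scatter), which is no change beyond the scatter. Compound 4 is estimated at 4.9, within the range 4.5 to 5.3.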

Compound 4, logarithm of the reciprocal of the active concentration, log(1/C): 5.12
Beside the measured number, compound 4's estimate is 0.22 log units below it; low and high end bracket the measured number.
By their numbers in this assay, from the lowest: compounds 2, 4, 3 and 1 (each within the scatter of the next, the first and the last beyond it).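

In this assay the move to 2-methoxyethyl from 1-methoxypropyl on this double-bonded ring carbon is a number 0.28 log units higher from compound 2 to compound 4 (within the scatter) and so counts as no real change, which shows that this position accepts this rearrangement of the chain around the methoxy group. The step of a number 0.19 log units lower from compound 1 to compound 4 (within the scatter) adds something new: a chain with no carbamoyloxy group can sit within the scatter of compound 1, which compound 2 did not do. No measurement at hand says why these chains behave this way.

On these data alone, how far this tolerance extends stays open: a longer chain such as 3-methoxypropyl, or a chain ending in a hydroxyl group, an amine or a carboxylic acid on the same ring carbon, could hold the number or lose it. A plain propyl chain there would test whether the methoxy oxygen matters at all.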